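A few compounds are considered here, and "the series" means these few. Any claim that something is new, unique, unknown or untested is made for them only; others in the source may bear on it.

In a functional assay on A2780 cells (Homo sapiens) for antiproliferative activity, read by resazurin assay, with a stated time of 72 h (a higher number here means a weaker inhibitor, a lower number a stronger inhibitor), compound 3 `CN(Cc1cccc(Cl)c1)C(=O)c1cc2c(Cc3ccccc3)n[nH]c2cc1O` gives 5300 nM, compound 2 `CN(Cc1cccc(F)c1)C(=O)c1cc2c(Cc3ccccc3)n[nH]c2cc1O` gives 5000 nM and compound 1 `CN(C(=O)c1cc2c(Cc3ccccc3)n[nH]c2cc1O)c1ccco1` gives 2500 nM. Compound 3 therefore sits level with compound 2 and beyond the scatter from compound 1.

Compound 4 `CCOc1ccc(CN(C)C(=O)c2cc3c(Cc4ccccc4)n[nH]c3cc2O)cc1` differs from compound 3 by 4-ethoxyphenyl in place of 3-chlorophenyl on a saturated chain carbon bound to an amide-type nitrogen, which amounts to 3-chlorobenzyl to 4-ethoxybenzyl. The closest evidence is chloro in place of fluoro, a 1.1-fold higher number from compound 2 to compound 3 (0.03 log units; within the scatter). The furan-2-yl replacements are also small, at a 2.0-fold higher number from compound 1 to compound 2 (0.30 log units; within the scatter) and a 2.1-fold higher number from compound 1 to compound 3 (0.33 log units; beyond the scatter). Among the measured compounds shown here, no measured compound carries an ethoxy group, so the evidence is indirect.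

In this assay no step beyond the scatter is expected, and the estimated step is a 1.1-fold lower number from compound 3 to compound 4 (0.03 log units; within the scatter). The estimate for compound 4 is 5000 nM, with an expected range of 2000 nM to 12000 nM.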

Compound 4, half-maximal inhibitory concentration: 3200 nM
Compound 4: the middle estimate sits 1.6-fold (0.19 log units) above what was measured; the range from low to high includes it.
By their numbers in this assay, from the lowest: compounds 1, 4, 2 and 3 (each within the scatter of the next, the first and the last beyond it).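

In this assay, 4-ethoxyphenyl in place of 3-chlorophenyl gives no step beyond the scatter (a 1.7-fold lower number from compound 3 to compound 4 (0.22 log units; within the scatter)), and the same holds against 3-fluorophenyl (a 1.6-fold lower number from compound 2 to compound 4 (0.19 log units; within the scatter)). Unlike compound 3, compound 4 also stays within the scatter of the furan-2-yl compound (a 1.3-fold higher number from compound 1 to compound 4 (0.11 log units; within the scatter)), so on this amide-type nitrogen the group that enters, with its ethoxy oxygen, is tolerated as far as these compounds show. No measurement is at hand that bears on a cause for these steps. On these data alone, whether an amine or a carboxylic acid on the benzyl ring, or a longer chain in place of the benzyl group, would give a step beyond the scatter remains open.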